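Nucleoside series: aryl group at the core, fluorophenyl next

The compounds below may be only part of what the source reports. "The series", "measured", "known", "first", "only" and "open" are said of these compounds alone.

Measured so far:
compound 1 `Cc1ccsc1-c1ncnc2c1ncn2C1O[C@H](CO)[C@@H](O)[C@H]1O`, 2500 nM
compound 2 `OC[C@H]1OC(n2cnc3c(-c4ccccn4)ncnc32)[C@H](O)[C@@H]1O`, 900 nM
compound 3 `Cc1csc(-c2ncnc3c2ncn3C2O[C@H](CO)[C@@H](O)[C@H]2O)c1`, 2900 nM

All three share one core and differ only in the aromatic group on it. In a functional assay on CCRF-CEM cells (Homo sapiens) for inhibition (a lower number here means a stronger inhibitor, a higher number a weaker inhibitor), compound 3 sits at the high end of the three numbers; its gap to compound 1 is within the scatter (a 1.2-fold higher number from compound 1 to compound 3 (0.06 log units; within the scatter)), whereas compound 2 is set apart by a modest step (a 3.2-fold higher number from compound 2 to compound 3 (0.51 log units; beyond the scatter)). The two thiophene-bearing compounds thus behave alike, and only the pyridin-2-yl compound gives a lower number (a 2.8-fold lower number from compound 1 to compound 2 (0.44 log units; beyond the scatter)).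

Compound 4 `OC[C@H]1OC(n2cnc3c(-c4ccc(F)cc4)ncnc32)[C@H](O)[C@@H]1O` is not yet measured. The change from compound 3: 4-fluorophenyl in place of 4-methylthiophen-2-yl on an aromatic carbon. Among the compounds with values here, no measured step puts a six-membered carbon-only ring in place of a thiophene, so the two steps toward pyridin-2-yl are the only guide, and they point to a lower number when a six-membered ring enters. The 4-fluorophenyl ring carries none of the acceptor count of pyridin-2-yl. A smaller shift than a 3.2-fold higher number from compound 2 to compound 3 (0.51 log units; beyond the scatter) is expected, with the scatter of this assay leaving the direction open. The number for compound 4 is therefore estimated at 2000 nM, range 600 nM to 6000 nM, which means an expected step of a 1.5-fold lower number from compound 3 to compound 4 (0.16 log units; within the scatter).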

Compound 4, half-maximal inhibitory concentration: 700 nM
Compound 4: the middle estimate sits 2.9-fold (0.46 log units) above what was measured, within the range that was stated.
By their numbers in this assay, from the lowest: compounds 4 and 2 (each within the scatter of the next); then compounds 1 and 3 (each within the scatter of the next).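

In this assay, the lower number at this position no longer belongs to pyridin-2-yl alone: 4-fluorophenyl also stands apart from both thiophene groups (a 4.1-fold lower number from compound 3 to compound 4 (0.62 log units; beyond the scatter); a 3.6-fold lower number from compound 1 to compound 4 (0.55 log units; beyond the scatter)), and it stays level with pyridin-2-yl (a 1.3-fold lower number from compound 2 to compound 4 (0.11 log units; within the scatter)). Within the data shown here, a ring nitrogen in the entering ring is therefore not required to reach this level, and across these four compounds the split runs between the six-membered and the five-membered aromatic rings, with no compound going against it. No measured evidence is available to explain this split.

Still open, as far as these compounds go, is how a plain phenyl group compares with 4-fluorophenyl, which would separate the part played by the ring from that of the fluorine. Also open, from the compounds shown here alone, is how the number moves with an amine, a carboxylic acid or a longer chain at this carbon.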